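Chloro to Dimethylamino: Expecting Another Limit in Cytotoxicity

This account rests on a few compounds, and the source may have more. Where it says the series, first, only, none or still open, it means among the compounds named here.

Three compounds share one core and differ only in a single group on a six-membered aromatic ring of carbon only. Compound 1 `COc1cc(/C=N/Nc2nc3ccccc3s2)ccc1O` and compound 2 `Clc1ccc(/C=N/Nc2nc3ccccc3s2)cc1` have been tested in a functional assay on MDA-MB-435 cells (Homo sapiens) for cytotoxicity, read by MTT assay, with a stated time of 72 h; a higher number here means a weaker inhibitor, a lower number a stronger inhibitor. For compound 1 the assay reaches only a limit, > 16700 nM, and gives no number. For compound 2 the result is likewise a limit, > 17300 nM. Compound 2 therefore stands on no number at all in this assay; the other measured value is a limit as well, seen in the limit of > 16700 nM in this assay, at which 1 of the 2 values shown sits. Compound 2 itself sits at the limit of > 17300 nM in this assay, at which 1 of the 2 values shown sits. Compound 3 `CN(C)c1ccc(/C=N/Nc2nc3ccccc3s2)cc1` has not yet been measured. It differs from compound 2 by dimethylamino in place of chloro on an aromatic carbon. Among the compounds with values here, no measured step between compounds exists here, so nothing shows how such a swap shifts the result in this assay. With both known values sitting at limits, compound 3 is expected to land in the same weak region, and the step that the limit leaves unreadable from compound 2 to compound 3 is expected to be no change beyond the scatter. The estimate for compound 3 is 20000 nM, with a range from 5000 nM to 60000 nM.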

Compound 3, half-maximal inhibitory concentration: > 16800 nM
Compound 3: no number, only a limit (the forecaster's own chance of this, stated with the estimate: 70%); the middle value is on the limit's open side.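

Compound 2 and compound 3 both end at limits of the assay rather than at numbers, so no step can be read for dimethylamino in place of chloro. The compounds shown leave open how strongly any of them acts in this assay, and whether changing this group can shift the result at all.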